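Adding a Propyl Chain to a Compound at the Limit

The source may hold more compounds than are shown below. What is called first, only, known or untested is meant among the compounds shown, and "the series" means these compounds.

Measured so far:
compound 1 `CCc1c(OC)nc2nc(-c3noc(C)n3)c(Cl)n2c1C` — 10 mg/kg
compound 2 `CCc1c(OC)nc2nc(-c3nnco3)cn2c1C` — > 50 mg/kg

In a functional assay on the whole organism with Rattus norvegicus as the target (a higher number here means that more compound is needed for the effect, a lower number that less compound is needed), compound 1 gives 10 mg/kg. For compound 2 the value > 50 mg/kg is a limit of the assay and not a number. Going by these compounds, this is the limit of > 50 mg/kg in this assay, at which 1 of the 2 values shown sits, so compound 2 stands at the edge of what the assay can report, and how far beyond it lies is unknown. Among the compounds with values here, no two measured compounds differ in a single place, so no step has been measured here.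

Compound 3 `CCCc1nnc(-c2cn3c(C)c(CC)c(OC)nc3n2)o1` differs from compound 2 by propyl in place of hydrogen on an aromatic carbon. The propyl enters without a ring and without hydrogen-bond donors or acceptors.

Within the data shown here, because compound 2 only reaches the limit > 50 mg/kg, no measured step guides the expectation. The step is expected to move toward less compound being needed, estimated as an at least 1.6-fold lower number from compound 2 to compound 3 (0.22 log units; that floor lies within the scatter), with considerable uncertainty. Compound 3 is therefore expected to give about 30 mg/kg, somewhere between 8 mg/kg and 100 mg/kg.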

Compound 3, minimum effective dose: 50 mg/kg
For compound 3 the middle estimate is 1.7-fold (0.22 log units) below the measured one; the measured number falls inside the stated range.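

The aromatic carbon of the five-membered ring with 2 nitrogen and 1 oxygen accepts a propyl chain, and with it a readable number appears: in this assay compound 3 gives 50 mg/kg. This is the only single change among the compounds shown, and it amounts to a number no higher from compound 2 to compound 3 (the limit leaves the size open). Compound 2 stands at a limit and not at a number, which is why the size of this step cannot be read: the limit of > 50 mg/kg in this assay, at which 1 of the 3 values shown sits.

The compounds shown leave open how much propyl really adds in place of hydrogen. They also leave open whether a longer chain such as butyl, or an amine, on this same carbon would bring the number lower than in compound 3.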